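Adding one methyl to a piperidine group

This account rests on a few compounds, and the source may have more. Where it says the series, first, only, none or still open, it means among the compounds named here.

Values in a physicochemical assay for solubility, read by HPLC, in phosphate buffer, measured as kinetic solubility, with a stated time of 1 h, at pH 7.4, tested at 250 uM (a higher number here means a more soluble compound, a lower number a less soluble compound), for the measured compounds

- compound 1 `CN1CCC(c2ccc3c(c2)oc(=O)n3C(=O)NCCCCc2ccccc2)CC1=O` gives 20000 nM as its value
- compound 2 `CCN1CCN(c2ccc3c(c2)oc(=O)n3C(=O)NCCCCc2ccccc2)CC1` gives < 1000 nM as a limit of the assay, not a number
- compound 3 `CN1CCC(c2ccc3c(c2)oc(=O)n3C(=O)NCCCCc2ccccc2)CC1` gives 120000 nM as its value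

Compound 3 holds the higher of the two true numbers, and the gap is a 6.0-fold higher number from compound 1 to compound 3 (0.78 log units; beyond the scatter) in a step beyond the scatter. Compound 4 `CCN1CCC(c2ccc3c(c2)oc(=O)n3C(=O)NCCCCc2ccccc2)CC1` differs from compound 3 in one place. The 1-methylpiperidin-4-yl group becomes 1-ethylpiperidin-4-yl, which means methyl in place of hydrogen on a saturated chain carbon bound to an amine nitrogen in a ring. Going by the values given here, no measured step makes this change alone. Among the compounds with values here, compound 2 is the only measured compound with an ethyl group, in 4-ethylpiperazin-1-yl, so the nearest guide is an at least 120-fold higher number from compound 2 to compound 3 (2.07 log units; beyond the scatter) as a large step. That step rests on the limit of < 1000 nM in this assay, at which 1 of the 3 values shown sits, and so gives only a bound on its size. It and the modest 6.0-fold higher number from compound 1 to compound 3 (0.78 log units; beyond the scatter) each replace a whole group, while compound 4 gains a single methyl. A far smaller step is therefore expected, downward in this assay if it shows beyond the scatter at all. The expected change is a 1.5-fold lower number from compound 3 to compound 4 (0.18 log units; within the scatter) as an estimate only. For compound 4 the estimated value is 80000 nM with an expected range from 25000 nM to 200000 nM in this assay once measured.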

Compound 4, solubility: 198000 nM
Beside the measured number, compound 4's estimate is 2.5-fold (0.39 log units) below it; the measured number falls inside the stated range.
By their numbers in this assay, from the lowest: compound 1; then compounds 3 and 4 (each within the scatter of the next). At a limit, below all of these: compound 2.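

Adding the methyl gives a 1.7-fold higher number from compound 3 to compound 4 (0.22 log units; within the scatter) in this assay, so at this saturated chain carbon bound to an amine nitrogen in a ring, 1-methylpiperidin-4-yl and 1-ethylpiperidin-4-yl cannot be told apart by this read-out. The larger gaps remain with the ethyl group in place: changing 1-methyl-2-oxopiperidin-4-yl to 1-ethylpiperidin-4-yl gives a 9.9-fold higher number from compound 1 to compound 4 (1.00 log units; beyond the scatter), while changing 4-ethylpiperazin-1-yl to 1-ethylpiperidin-4-yl gives an at least 190-fold higher number from compound 2 to compound 4 (2.29 log units; beyond the scatter), which also shows that an ethyl group on a ring nitrogen does not by itself go with a low reading. The second of those steps gives only a bound, and compound 2's reading is a limit rather than a number: the limit of < 1000 nM in this assay, at which 1 of the 4 values shown sits.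

From the compounds shown here alone, how far this tolerance extends remains open, since a longer chain such as propyl or a branched isopropyl group could behave differently from ethyl at this place. The compounds shown also leave open what a piperidine with hydrogen in place of the methyl, or a carboxylic acid on the ethyl chain, would give in this assay.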